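The source may report more compounds than this note shows. Statements on the series, on what has been measured and on what is new or still open speak of the compounds shown alone.

Compounds measured so far:
compound 1 `Cc1cc(C)c(S(C)(=O)=O)cc1C(=O)N=C(N)N`, 11 nM
compound 2 `Cc1cc(Oc2ccccc2Cl)c(S(C)(=O)=O)cc1C(=O)N=C(N)N`, 14 nM

Compound 2 has the highest of the two numbers in a functional assay for inhibition of sodium/hydrogen exchanger (Oryctolagus cuniculus); on this read-out lower numbers stand for stronger inhibition and higher numbers for weaker inhibition; its nearest neighbour is compound 1, and the step of a 1.3-fold higher number from compound 1 to compound 2 (0.10 log units; within the scatter) lies within the scatter, so the two compounds are not distinguished by this read-out. Compound 3 `Cc1cc(N2CCCCC2)c(S(C)(=O)=O)cc1C(=O)N=C(N)N` is not yet measured. It differs from compound 2 in one place: piperidin-1-yl in place of 2-chlorophenoxy on an aromatic carbon. Going by the values given here, the only measured step that bears on this position is the one from compound 1 to compound 2, where a small group gave way to a larger ring-bearing one without a change beyond the scatter. On that basis the exchange for a piperidin-1-yl group is expected to leave this assay largely unchanged, with at most a modest shift towards a higher number. The estimate for compound 3 is 20 nM, with a range from 6 nM to 70 nM, corresponding to an expected step of a 1.4-fold higher number from compound 2 to compound 3 (0.15 log units; within the scatter).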

Compound 3, half-maximal inhibitory concentration: 21 nM
Beside the measured number, compound 3's estimate is 1.1-fold (0.02 log units) below it; low and high end bracket the measured number.
By their numbers in this assay, from the lowest: compounds 1, 2 and 3 (each within the scatter of the next).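

In this assay, the exchange of the aromatic 2-chlorophenoxy for the non-aromatic piperidin-1-yl gives a 1.5-fold higher number from compound 2 to compound 3 (0.18 log units; within the scatter), and the exchange of methyl for the same ring gives a 1.9-fold higher number from compound 1 to compound 3 (0.28 log units; within the scatter). Going by these compounds alone, the position had so far been seen only with methyl and 2-chlorophenoxy; it now also carries a non-aromatic ring joined through its nitrogen, and this read-out still separates none of the three groups, though they differ in size and ring type. No supporting measurement is available to explain this result.

The compounds shown leave open whether a carboxylic acid, a primary amine or a longer alkyl chain on this aromatic carbon would move the number beyond the scatter. They also leave open whether a smaller ring such as pyrrolidin-1-yl, or a morpholin-4-yl ring with its added oxygen, would behave as piperidin-1-yl does.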